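The source may report more compounds than this note shows. Statements on the series, on what has been measured and on what is new or still open speak of the compounds shown alone.

Measured in a functional assay on HCT-116 cells (Homo sapiens) for antiproliferative activity, read by MTT assay; on this read-out higher numbers stand for weaker inhibition and lower numbers for stronger inhibition:
Compound 1 `Cc1cccc(/C=N/Nc2ncc3c(n2)n(C2CCCC2)c(=O)c(=O)n3C)c1`: > 100000 nM, a limit of the assay and not a number
Compound 2 `COc1cccc(/C=N/Nc2ncc3c(n2)n(C2CCCC2)c(=O)c(=O)n3C)c1`: 45800 nM
Compound 3 `Cn1c(=O)c(=O)n(C2CCCC2)c2nc(N/N=C/c3cccc(Cl)c3Cl)ncc21`: 26400 nM

Only compound 2 and compound 3 have actual numbers in this assay, and a 1.7-fold lower number from compound 2 to compound 3 (0.24 log units; within the scatter) leaves the two unresolved. Compound 3 therefore stands level with compound 2 at the low end of this small set, and clear of compound 1, which gives only (the limit of > 100000 nM in this assay, at which 1 of the 3 values shown sits).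

Compound 4 `Cn1c(=O)c(=O)n(C2CCCC2)c2nc(N/N=C/c3ccc(F)cc3Cl)ncc21` changes compound 3 at one place: 2-chloro-4-fluorophenyl in place of 2,3-dichlorophenyl on a carbon with a double bond to nitrogen. Going by the values given here, no measured step makes this exact exchange, but two steps replace the aromatic group at that same place. One is an at least 3.7-fold lower number from compound 1 to compound 3 (0.57 log units; beyond the scatter), which is bounded by a limit and so gives no exact size. The other is a 1.7-fold lower number from compound 2 to compound 3 (0.24 log units; within the scatter). A third, an at least 2.1-fold lower number from compound 1 to compound 2 (0.33 log units; beyond the scatter), shows that a change of substituent on that aromatic group can register, though only modestly on this evidence.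

With so little to go on, no step beyond the scatter is expected in this assay, and no direction can be firmly assigned. The expected change is a 1.3-fold lower number from compound 3 to compound 4 (0.12 log units; within the scatter). For compound 4 the estimated value is 20000 nM, with an expected range from 4000 nM to 70000 nM.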

Compound 4, half-maximal inhibitory concentration: 13800 nM
For compound 4 the middle estimate is 1.4-fold (0.16 log units) above the measured one; low and high end bracket the measured number.
By their numbers in this assay, from the lowest: compounds 4, 3 and 2 (each within the scatter of the next, the first and the last beyond it). At a limit, above all of these: compound 1.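

In this assay, the exchange on a carbon with a double bond to nitrogen gives a 1.9-fold lower number from compound 3 to compound 4 (0.28 log units; within the scatter), so 2-chloro-4-fluorophenyl and 2,3-dichlorophenyl cannot be told apart at this position, even though the two groups differ in one halogen and in where the halogens sit. Set against 3-methoxyphenyl, the new group gives a 3.3-fold lower number from compound 2 to compound 4 (0.52 log units; beyond the scatter), and this is the first step beyond the scatter at this position in which both ends are actual numbers, so the aromatic group here can be shown to matter without leaning on a limit. Against 3-methylphenyl the reading is an at least 7.2-fold lower number from compound 1 to compound 4 (0.86 log units; beyond the scatter), and the size of that step stays open-ended, since compound 1 gives a limit and not a number: the limit of > 100000 nM in this assay, at which 1 of the 4 values shown sits.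

The compounds shown do not separate the part played by the chlorine from that of the fluorine in 2-chloro-4-fluorophenyl, since no aromatic group here carries either halogen alone at the same place. They also leave open how an amine or a carboxylic acid on that aromatic group would read in this assay, and whether any group at this place would reach much lower numbers.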